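This account rests on a few compounds, and the source may have more. Where it says the series, first, only, none or still open, it means among the compounds named here.

Measured in a functional assay on NCI-H460 cells (Homo sapiens) for cytotoxicity, read by MTT assay, with a stated time of 3 days; a lower number here means a stronger inhibitor, a higher number a weaker inhibitor:
- Compound 1 `N#Cc1c(Cl)nc(SCc2nc3ccccc3[nH]2)nc1-c1ccccc1`: 3.28 nM
- Compound 2 `N#Cc1c(NC(N)=S)nc(SCc2nc3ccccc3[nH]2)nc1-c1ccccc1`: 3.37 nM

Only these two numbers exist so far, and they cannot be told apart. Within the data shown here, the measured difference is a 1.0-fold higher number from compound 1 to compound 2 (0.01 log units; within the scatter), so compound 2 stands level with the only other measured compound.

Compound 3 `CN1CCN(c2nc(SCc3nc4ccccc4[nH]3)nc(-c3ccccc3)c2C#N)CC1` keeps the shared core and differs in one place. A 4-methylpiperazin-1-yl group enters on an aromatic carbon of a six-membered aromatic ring with 2 nitrogen, ortho to a cyano group: a group of 7 heavy atoms (5 carbon, 2 nitrogen; one six-membered non-aromatic ring with 2 hetero atoms) in place of a group of 4 heavy atoms (1 carbon, 2 nitrogen, 1 sulfur; no ring), on an aromatic carbon.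

Among the measured compounds shown here, one measured step bears on this change, as it alters the same carbon. That step, a 1.0-fold higher number from compound 1 to compound 2 (0.01 log units; within the scatter), replaced one chlorine atom and left the number within the scatter. For the measured compounds named here, it is a single step, however, and no measured compound carries a ring at this carbon. The data therefore give no reason to expect a shift in either direction, but they leave real uncertainty. In this assay the expected change is a 1.0-fold higher number from compound 2 to compound 3 (0.02 log units; within the scatter), which is no change beyond the scatter. For compound 3 the estimated value is 3.5 nM, with an expected range from 1 nM to 12 nM.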

Compound 3, half-maximal inhibitory concentration: 2.84 nM
Compound 3: middle estimate off by 1.2-fold (0.09 log units), on the high side; the range from low to high includes it.
By their numbers in this assay, from the lowest: compounds 3, 1 and 2 (each within the scatter of the next).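

In this assay, among these compounds, the carbon ortho to the cyano group now carries a ring for the first time, and the 4-methylpiperazin-1-yl group gives no change that can be told from the scatter, whether set against the group it replaces in compound 2 (a 1.2-fold lower number from compound 2 to compound 3 (0.07 log units; within the scatter)) or against the chloro group of compound 1 (a 1.2-fold lower number from compound 1 to compound 3 (0.06 log units; within the scatter)). Across these three compounds, this carbon has held a single chlorine atom, an open group with 2 hydrogen-bond donors and a ring with 0 hydrogen-bond donors, and the numbers stay level within the scatter, so in this small set the size and the ring of the group make no visible difference. Nothing measured here explains this flat result.

From the compounds shown here alone, whether a small amine, a carboxylic acid or a longer chain on this carbon would also leave the number level remains open. The three compounds share everything else, so they also say nothing about how the number responds to a change in the phenyl group or elsewhere on the shared core.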